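The compounds below may be only part of what the source reports. "The series", "measured", "known", "first", "only" and "open" are said of these compounds alone.

In an ADME assay on Vero cells (Chlorocebus sabaeus) for cytotoxicity, read by MTT assay, with a stated time of 72 h (a lower number here means that less compound is tolerated, a higher number that more compound is tolerated), compound 1 `C[C@]1(CN2CCc3nc(C4CCCCC4)ccc3C2)Cn2cc([N+](=O)[O-])nc2O1` carries the entry "not determined" (no result reported). Compound 2 `C[C@]1(CN2CCc3nc(C(F)(F)F)ccc3C2)Cn2cc([N+](=O)[O-])nc2O1` carries the entry "not determined" (no result reported). Compound 3 `C[C@]1(CN2CCc3nc(-c4ccc(F)c(Cl)c4)ccc3C2)Cn2cc([N+](=O)[O-])nc2O1` gives > 32 ug/mL, which is a limit and not a number, so it is the only result in the series and fixes no exact position.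

Compound 4 `C[C@]1(CN2CCc3nc(-c4cccc(Cl)c4F)ccc3C2)Cn2cc([N+](=O)[O-])nc2O1` has 3-chloro-2-fluorophenyl in place of 3-chloro-4-fluorophenyl on an aromatic carbon, with the same atoms joined differently: 3-chloro-2-fluorophenyl in place of 3-chloro-4-fluorophenyl on an aromatic carbon.

Within the data shown here, no measured pair gives a size for such a change, so no shift beyond the usual scatter is expected in this assay, in either direction. The estimated step that the limit leaves unreadable from compound 3 to compound 4 is read in that light. For compound 4 the expected value is 40 ug/mL, with an estimated range of 20 ug/mL to 80 ug/mL.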

Compound 4, half-maximal cytotoxic concentration: > 32 ug/mL
Compound 4 was reported as a limit; the forecaster's own chance of this, stated with the estimate: 80%; the middle value is on the limit's open side.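

No step can be read between compound 3 and compound 4, since both entries are limits and not numbers: the limit of > 32 ug/mL in this assay, at which 2 of the 4 values shown sit.

The compounds shown leave open whether 3-chloro-2-fluorophenyl in place of 3-chloro-4-fluorophenyl changes the result in this assay at all.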